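Aryl ether chain extension in the ketone series

The source may report more compounds than this note shows. Statements on the series, on what has been measured and on what is new or still open speak of the compounds shown alone.

Measured so far:
compound 1 `COc1ccc([C@@H]2C/C(=N/OCc3cn(-c4ccccc4CO)nn3)c3cc(CC=C(C)C)c(OC)cc3O2)cc1`: 100%
compound 2 `COc1ccc([C@@H]2CC(=O)c3cc(CC=C(C)C)c(OC)cc3O2)cc1`: 45%
compound 3 `COc1ccc([C@@H]2C/C(=N/OCc3cn(-c4ccc(C#N)cc4)nn3)c3cc(CC=C(C)C)c(OC)cc3O2)cc1`: 42%

In a functional assay on A549 cells (Homo sapiens) for inhibition, read by sulforhodamine B assay, with a stated time of 48 h, tested at 50 uM (a higher number here means more inhibition of growth at the concentration tested, a lower number less inhibition of growth), compound 2 gives 45%, the second highest of the three numbers. Compound 3 is nearest, with a value within the scatter of compound 2, so no order between them is claimed; compound 1 lies far above both, beyond the scatter.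

Among the measured compounds shown here, the one step measured concerns the oxime ether side chain: a number 58 percentage points lower from compound 1 to compound 3 (beyond the scatter). That step touches a part of the molecule that compound 2 and compound 4 `CCCOc1ccc([C@@H]2CC(=O)c3cc(CC=C(C)C)c(OC)cc3O2)cc1` do not carry, so it does not bear on the present change.

The change from compound 2 to compound 4 is ethyl in place of hydrogen on a saturated chain carbon bound to an oxygen on an aromatic ring, that is methoxy to propoxy on the aryl ether. For the measured compounds named here, no measured pair varies this position, and no other pair here involves the aryl ether at all. Without a comparable step, the working expectation is no change beyond the scatter in this assay, the estimated step being no change at the digits printed from compound 2 to compound 4 (within the scatter). Going by the values given here, compound 4 is therefore expected to give about 45%, with a range from 25% to 65%; the range is kept wide, since the only measured step in this set shows that single changes can move the value far.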

Compound 4, percent growth inhibition at one concentration: 43%
Beside the measured number, compound 4's estimate is 2 percentage points above it; the measured number falls inside the stated range.
By their numbers in this assay, from the lowest: compounds 3, 4 and 2 (each within the scatter of the next); then compound 1.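

In this assay, among the compounds shown here, the first measured change at the aryl ether, methoxy to propoxy, gives a number 2 percentage points lower from compound 2 to compound 4 (within the scatter) and so leaves the two ketones indistinguishable in this read-out. In this ketone pair, the position on a saturated chain carbon bound to an oxygen on an aromatic ring therefore takes an added ethyl, with its 2 heavy atoms, without a shift beyond the scatter, whereas the side-chain step of a number 58 percentage points lower from compound 1 to compound 3 (beyond the scatter) was large. Nothing available explains why compound 2 and compound 4 read alike.

Going by these compounds, the result covers only methoxy and propoxy on the ketone, so it remains open whether a longer chain such as hexyloxy, or a chain carrying an amine or a carboxylic acid, would also stay within the scatter of compound 2 in this assay as this pair does. On these data alone, it is also open whether compound 1, at 100% in the oxime ether series, would keep its number with propoxy in place of methoxy, since this single step comes from the ketone series alone.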